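A few compounds are considered here, and "the series" means these few. Any claim that something is new, unique, unknown or untested is made for them only; others in the source may bear on it.

Measured in an ADME assay on cells (Hepatocyte, Homo sapiens) for metabolic stability; on this read-out lower numbers stand for a shorter-lived compound and higher numbers for a longer-lived compound:
- compound 1 `CS(=O)(=O)NC1CCC(CN2CCN(c3cc(=O)c4cc(C(F)(F)F)cc([N+](=O)[O-])c4s3)CC2)CC1` gives > 1.55 h (a limit of the assay)
- compound 2 `O=C(OC1CCC(CN2CCN(c3cc(=O)c4cc(C(F)(F)F)cc([N+](=O)[O-])c4s3)CC2)CC1)c1ccncc1` gives 0.075 h

Within the data shown here, compound 2 holds the only actual number in this assay, 0.075 h. For compound 1, the result of > 1.55 h is a limit and not a number.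

The next compound, compound 3 `O=C(OC1CCC(CN2CCN(c3cc(=O)c4cc(C(F)(F)F)cc([N+](=O)[O-])c4s3)CC2)CC1)c1ccc(C(F)(F)F)cc1`, differs from compound 2 at one place: 4-(trifluoromethyl)phenyl in place of pyridin-4-yl on a carbonyl carbon. In words, 4-(trifluoromethyl)phenyl stands in place of pyridin-4-yl on a carbonyl carbon. Among the measured compounds shown here, no measured step covers this exchange directly. For the measured compounds named here, the one step available, an at least 20-fold lower number from compound 1 to compound 2 (1.31 log units; beyond the scatter), was large and beyond the scatter, but it arose from placing ((pyridin-4-yl)carbonyl)oxy in place of methanesulfonamido on a saturated ring carbon. Compound 3 keeps the carbonyl and its oxygen at that ring carbon, and only the group on the carbonyl carbon changes. The short half-life of compound 2 at 0.075 h is therefore the best guide, and no step beyond the scatter is expected in either direction. The expected change is a 1.1-fold higher number from compound 2 to compound 3 (0.05 log units; within the scatter). For compound 3 the estimated half-life is 0.085 h, with an expected range from 0.03 h to 0.25 h.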

Compound 3, half-life: 0.117 h
The estimate for compound 3 lay 1.4-fold (0.14 log units) below the measured number; the measured number falls inside the stated range.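

In this assay, the exchange at the carbonyl carbon gives a 1.6-fold higher number from compound 2 to compound 3 (0.19 log units; within the scatter), so an aromatic ring of carbon only carrying trifluoromethyl and a ring with one hetero atom cannot be told apart on this read-out. The earlier large step, an at least 20-fold lower number from compound 1 to compound 2 (1.31 log units; beyond the scatter), is therefore not tied to pyridin-4-yl alone: with 4-(trifluoromethyl)phenyl on the carbonyl carbon, compound 3 still gives 0.117 h. Compound 1, the only compound with methanesulfonamido on the saturated ring carbon, remains a limit and not a number: the limit of > 1.55 h in this assay, at which 1 of the 3 values shown sits.

What the compounds shown leave open is whether the short half-life goes with the carbonyl and its oxygen as a unit, which an amide nitrogen in place of that oxygen, or a simple ether on the same ring carbon, would test. Going by these compounds, it also remains open how far the group on the carbonyl carbon can vary, since a saturated ring such as piperidine, a short alkyl chain or an amine there could either stay within the scatter of compound 2 or move beyond it.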